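A few compounds are considered here, and "the series" means these few. Any claim that something is new, unique, unknown or untested is made for them only; others in the source may bear on it.

Measured so far in a physicochemical assay for lipophilicity, measured as octanol-water partition, at pH 7.4; on this read-out higher numbers stand for higher lipophilicity and lower numbers for lower lipophilicity:
compound 1 `Cc1csc(C(=O)N[C@H]2CN(S(=O)(=O)c3ccccc3)C[C@@H]2C(=O)N[C@H]2CCCNC2)n1`: 0.1
compound 2 `O=C(N[C@H]1CN(S(=O)(=O)c2ccccc2)C[C@@H]1C(=O)N[C@H]1CCCNC1)c1cc(C2CC2)n[nH]1`: 0.2
compound 3 `O=C(N[C@H]1CN(S(=O)(=O)c2ccccc2)C[C@@H]1C(=O)N[C@H]1CCCNC1)c1cn(C2CC2)cn1`: -0.7

Of these three, compound 3 has the lowest number. Two measured steps lead down to it, a number 0.80 log units lower from compound 1 to compound 3 (beyond the scatter) and a number 0.90 log units lower from compound 2 to compound 3 (beyond the scatter), and both are modest. By contrast, a number 0.10 log units higher from compound 1 to compound 2 (within the scatter).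

Compound 4 `O=C(N[C@H]1CN(S(=O)(=O)c2ccccc2)C[C@@H]1C(=O)N[C@H]1CCCNC1)c1cc(-c2ccccc2)on1` is still unmeasured. Its structural change is 5-phenyl-1,2-oxazol-3-yl in place of 1-cyclopropyl-1H-imidazol-4-yl on a carbonyl carbon. Within the data shown here, no measured step brings in 5-phenyl-1,2-oxazol-3-yl, so the evidence is indirect. Compound 3 sits lowest among the three, with a number 0.80 log units lower from compound 1 to compound 3 (beyond the scatter) and a number 0.90 log units lower from compound 2 to compound 3 (beyond the scatter), so replacing its 1-cyclopropyl-1H-imidazol-4-yl group is expected to move the number upward. The entering group differs from all three measured groups, and the expected move is therefore somewhat larger than those steps and quite uncertain. The expected step is a number 1.50 log units higher from compound 3 to compound 4 (beyond the scatter). For compound 4 the estimated value is 0.8, with an expected range from 0.2 to 1.5.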

Compound 4, distribution coefficient: 1.3
Compound 4: middle estimate off by 0.50 log units, on the low side; the measured number falls inside the stated range.
By their numbers in this assay, from the lowest: compound 3; then compounds 1 and 2 (each within the scatter of the next); then compound 4.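

Among these compounds, at this position, on a carbonyl carbon whose other neighbour is the amide-type nitrogen, the earlier exchanges of one ring group for another gave at most modest steps in this assay. 5-Phenyl-1,2-oxazol-3-yl is the first group to give large steps, and it does so against all three earlier groups (a number 2.00 log units higher from compound 3 to compound 4 (beyond the scatter) and a number 1.10 log units higher from compound 2 to compound 4 (beyond the scatter) and a number 1.20 log units higher from compound 1 to compound 4 (beyond the scatter)), which leaves compound 4 with the highest number of the four. Nothing measured here accounts for the size of these steps.

The compounds shown do not separate the share of the phenyl ring from that of the 1,2-oxazole ring, as no pair differs in only one of them. As far as these compounds go, how a 5-methyl-1,2-oxazol-3-yl group, or a pyridyl ring in place of the phenyl, would read in this assay remains open.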